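The source may report more compounds than this note shows. Statements on the series, on what has been measured and on what is new or still open speak of the compounds shown alone.

Compound 1 `O=C(Nc1ccc(C(F)(F)F)cc1)c1cc(Br)ccc1O` carries the shared core with a free phenol. In a physicochemical assay for solubility, read by spectrophotometry (on this read-out lower numbers stand for lower solubility and higher numbers for higher solubility), compound 1 gives < 100000 nM, which is a limit of the assay and not a number. Compound 2 `O=C(NCCCCl)Oc1ccc(Br)cc1C(=O)Nc1ccc(C(F)(F)F)cc1` carries the (3-chloropropyl)carbamoyl on the oxygen of that ring. In this assay compound 2 gives < 50000 nM, again a limit rather than a number. The step that the two limits leave unreadable from compound 1 to compound 2 cannot be read, since the limit of < 100000 nM in this assay, at which 1 of the 2 values shown sits, and the limit of < 50000 nM in this assay, at which 1 of the 2 values shown sits, cap both values from the same side. Compound 2 therefore stands only at a limit, and no numerical solubility is known for it. Compound 3 `O=C(NCCCCl)Oc1ccc(Br)cc1C(=O)Nc1ccc(C(=O)c2ccccc2)cc1` differs from compound 2 in one place: benzoyl in place of trifluoromethyl on an aromatic carbon. Among the compounds with values here, no measured step bears on this exchange; the single step, that of the carbamate, is unreadable, so neither size nor direction can be taken from it. Compound 2 gives only a limit, and compound 3 is expected to stay in the poorly soluble region, with an estimated step that the limit leaves unreadable from compound 2 to compound 3. The estimated value for compound 3 is 15000 nM, with a range from 3000 nM to 50000 nM.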

Compound 3, solubility: < 50000 nM
Compound 3: no number, only a limit (the forecaster's own chance of this, stated with the estimate: 50%); the middle value lies beyond the limit too.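

In this assay compound 3 gives < 50000 nM, a limit of the assay and not a number. No step from compound 2 to compound 3 can be read, since both stand at the same limit: the limit of < 50000 nM in this assay, at which 2 of the 3 values shown sit.

The compounds shown leave open the numerical solubility of compound 1, compound 2 and compound 3, and whether benzoyl or trifluoromethyl gives the higher value.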